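This account rests on a few compounds, and the source may have more. Where it says the series, first, only, none or still open, it means among the compounds named here.

Working notes on the series. The shared core of compound 1 `O=C(c1ccc(-c2nc(-c3ccc(C(F)(F)F)cc3)no2)s1)C(F)(F)F` and compound 2 `O=C(c1ccc(-c2nc(-c3cccnc3)no2)s1)C(F)(F)F` is held constant; the two differ in the group attached to the aromatic carbon between the two ring nitrogen atoms. In an assay on isolated protein for inhibition of protein deacetylase HDAC6 (Homo sapiens) (on this read-out lower numbers stand for stronger inhibition and higher numbers for weaker inhibition), compound 1 gives 11000 nM, whereas in this assay compound 2 gives 840 nM. Compound 2 therefore holds the lowest of the two numbers on this read-out, and its gap to compound 1 lies beyond the scatter.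

Compound 3 `O=C(c1ccc(-c2nc(-c3ccc(F)cc3F)no2)s1)C(F)(F)F` is the next member to be measured. Its difference from compound 2 is 2,4-difluorophenyl in place of pyridin-3-yl on an aromatic carbon. The group that enters carries no hydrogen-bond acceptor, while the pyridin-3-yl that leaves carries one; compound 1, which also carries a carbon-only six-membered ring at this place, gave the higher number of the two. On that basis a move from compound 2 to compound 3 is expected to weaken inhibition by a 3.6-fold higher number from compound 2 to compound 3 (0.55 log units; beyond the scatter), beyond the scatter but short of the full gap between compound 2 and compound 1. For compound 3 the expected value in this assay is 3000 nM, with a range from 1000 nM to 10000 nM.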

Compound 3, half-maximal inhibitory concentration: 580 nM
Beside the measured number, compound 3's estimate is 5.2-fold (0.71 log units) above it; the measured number lies below the stated range.
By their numbers in this assay, from the lowest: compounds 3 and 2 (each within the scatter of the next); then compound 1.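

Putting 2,4-difluorophenyl in place of pyridin-3-yl on the aromatic carbon between two ring nitrogen atoms gives a 1.4-fold lower number from compound 2 to compound 3 (0.16 log units; within the scatter) in this assay, so compound 2 and compound 3 cannot be told apart on this read-out. A hydrogen-bond acceptor on the group at this place is thus not needed for a number in this range, and a carbon-only six-membered ring at this place does not by itself go with the much higher number of compound 1, which gives 11000 nM on the same read-out. No measurement on the series gives a cause for this result.

The compounds shown leave open what sets the trifluoromethyl-bearing ring of compound 1 apart from the 2,4-difluorophenyl of compound 3, and whether an unsubstituted phenyl or a phenyl with a single fluorine would read like compound 3 or like compound 1. Also open, as far as these compounds go, is how a group of a different kind at this place, such as an amine, a carboxylic acid or a saturated ring like morpholine, would read.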